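A few compounds are considered here, and "the series" means these few. Any claim that something is new, unique, unknown or untested is made for them only; others in the source may bear on it.

Working notes on the series. Among the compounds with values here, in a functional assay on A549 cells (Homo sapiens) for cytotoxicity, read by MTT assay, with a stated time of 72 h (on this read-out lower numbers stand for stronger inhibition and higher numbers for weaker inhibition), compound 1 (`O=C1c2c[n+]([O-])c3ccccc3c2C(=O)c2c1c1ccccc1n2Cc1cn([C@@H]2C[C@H](O)[C@@H](CO)O2)nn1`) gives 120 nM and stands lowest of the three numbers so far. Compound 2 (`O=C1c2c[n+]([O-])c3ccccc3c2C(=O)c2c1c1ccccc1n2CCCCN1CCNCC1`) gives 540 nM and compound 3 (`CCCCN1CCN(CCCCn2c3c(c4ccccc42)C(=O)c2c[n+]([O-])c4ccccc4c2C3=O)CC1`) gives 550 nM and both lie above compound 1 beyond the scatter.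

Compound 4 (`CC1(C)O[C@@H](CO)[C@H](Cn2cc(Cn3c4c(c5ccccc53)C(=O)c3c[n+]([O-])c5ccccc5c3C4=O)nn2)O1`) keeps the core of compound 1 and carries (5-(hydroxymethyl)-2,2-dimethyl-1,3-dioxolan-4-yl)methyl in place of 4-hydroxy-5-(hydroxymethyl)oxolan-2-yl on an aromatic nitrogen. Within the data shown here, the only measured step (a 1.0-fold higher number from compound 2 to compound 3 (0.01 log units; within the scatter)) is butyl in place of hydrogen on an amine nitrogen in a ring. Among the measured compounds shown here, it lies within the scatter but concerns a different side chain, so it bears only weakly on this exchange, and no measured step covers the exchange itself.

Compound 1 holds the lowest number at (120 nM), so a modest move toward weaker inhibition is expected in this assay rather than a further fall. The estimated step is small (a 1.7-fold higher number from compound 1 to compound 4 (0.22 log units; within the scatter)) and uncertain. For compound 4 the expected value is 200 nM (estimated range 70 nM to 600 nM).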

Compound 4, half-maximal inhibitory concentration: 370 nM
Compound 4: the middle estimate sits 1.9-fold (0.27 log units) below what was measured; the measured number falls inside the stated range.
By their numbers in this assay, from the lowest: compound 1; then compounds 4, 2 and 3 (each within the scatter of the next).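

In this assay, (5-(hydroxymethyl)-2,2-dimethyl-1,3-dioxolan-4-yl)methyl in place of 4-hydroxy-5-(hydroxymethyl)oxolan-2-yl on the aromatic nitrogen gives a 3.1-fold higher number from compound 1 to compound 4 (0.49 log units; beyond the scatter). Within the data shown here, this is the first step read at this position, and it shows that the number responds to the group on this nitrogen, though the cytotoxicity stays measurable after an exchange that brings 1 hydrogen-bond donor in place of 2 hydrogen-bond donors and a ring with 2 hetero atoms in place of one with 1 hetero atom. No measured evidence accounts for the step.

The compounds shown leave open which part of the exchange carries the step: the ring, the 2,2-dimethyl groups or the hydrogen-bond donor count. Also open, as far as these compounds go, is how an amine or a carboxylic acid on this nitrogen would read in this assay.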